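A few compounds are considered here, and "the series" means these few. Any claim that something is new, unique, unknown or untested is made for them only; others in the source may bear on it.

In a functional assay on HeLa cells (Homo sapiens) for cytotoxicity (on this read-out lower numbers stand for stronger inhibition of growth and higher numbers for weaker inhibition of growth), compound 1 (`COc1ccc(NS(=O)(=O)c2c(F)c(F)c(F)c(Br)c2F)cc1`) gives 220 nM and compound 2 (`COc1ccc(NS(=O)(=O)c2c(F)cc(F)c(F)c2F)cc1`) gives 5800 nM as the higher of the two numbers. Among the compounds with values here, the only measured step is a 26-fold higher number from compound 1 to compound 2 (1.42 log units; beyond the scatter) and it is large, with hydrogen in place of bromo on an aromatic carbon. Compound 3 (`COc1ccc(NS(=O)(=O)c2c(F)c(F)c(F)c(F)c2F)cc1`) alters that same carbon of compound 2, with fluoro in place of hydrogen on an aromatic carbon. Fluoro is not bromo and that single step is only a rough guide, yet a large move to a lower number is expected, with a 19-fold lower number from compound 2 to compound 3 (1.29 log units; beyond the scatter) estimated in this assay as the likely size. The expected value for compound 3 is 300 nM within a range of 70 nM to 1300 nM in this estimate.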

Compound 3, concentration for 50% growth inhibition: 99 nM
The estimate for compound 3 lay 3.0-fold (0.48 log units) above the measured number, within the range that was stated.
By their numbers in this assay, from the lowest: compound 3; then compound 1; then compound 2.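

In this assay, fluoro in place of hydrogen on this carbon gives a 59-fold lower number from compound 2 to compound 3 (1.77 log units; beyond the scatter), so the large gain seen with bromo is not confined to bromo. The choice between these two halogens matters much less, with fluoro in place of bromo giving a 2.2-fold lower number from compound 1 to compound 3 (0.35 log units; beyond the scatter), a modest step. Nothing available explains why either halogen on this carbon has this effect. The compounds shown carry only hydrogen, fluoro or bromo here, so how chloro, a methyl group or an amine on this carbon would compare stays open.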